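The source may hold more compounds than are shown below. What is called first, only, known or untested is meant among the compounds shown, and "the series" means these compounds.

Compound 1 `COc1ccc(-c2csc(NC(=O)COc3ccc(C(=O)c4ccc(C)cc4)cc3C)n2)cc1` gives 18700 nM in a functional assay on DLA cells (Mus musculus) for cytotoxicity, read by LDH release, with a stated time of 48 h; on this read-out lower numbers stand for stronger inhibition and higher numbers for weaker inhibition. Compound 2 `COc1ccc(-c2csc(NC(=O)COc3ccc(C(=O)c4ccc(F)cc4)cc3C)n2)cc1` gives 5500 nM in this assay, and compound 3 `Cc1cc(C(=O)c2ccccc2F)ccc1OCC(=O)Nc1nc(-c2ccccc2)cs1` gives 15600 nM. From compound 2 to compound 1 the change is methyl in place of fluoro on an aromatic carbon, and the step measured for it is a 3.4-fold higher number from compound 2 to compound 1 (0.53 log units; beyond the scatter). Compound 4 `Cc1cc(C(=O)c2ccccc2C)ccc1OCC(=O)Nc1nc(-c2ccccc2)cs1` is not yet measured; from compound 3 it differs by methyl in place of fluoro on an aromatic carbon. The difference between the core of compound 3 and the core of compound 2 is not broken down here. The change in compound 4 is the same kind of change as that in compound 1, but the place is not the same: para to a large group in compound 1, ortho to a large group in compound 4. A weaker number is expected for compound 4 because a 3.4-fold higher number from compound 2 to compound 1 (0.53 log units; beyond the scatter), with wider uncertainty from the different place. For compound 4 the expected step is a 2.2-fold higher number from compound 3 to compound 4 (0.35 log units; beyond the scatter) in this assay. Compound 4 is expected at 35000 nM, within 12000 nM to 100000 nM.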

Compound 4, half-maximal inhibitory concentration: 23700 nM
The estimate for compound 4 lay 1.5-fold (0.17 log units) above the measured number, and the stated range covers the measured number.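

In this assay, methyl in place of fluoro on the core of compound 3 gives a 1.5-fold higher number from compound 3 to compound 4 (0.18 log units; within the scatter), so on this core the change cannot be told apart from repeat scatter. Set beside the earlier step, the two cores do not separate: the same change on two cores in this assay, a 3.4-fold higher number (0.53 log units; beyond the scatter) from compound 2 to compound 1 and a 1.5-fold higher number (0.18 log units; within the scatter) from compound 3 to compound 4, 2.2-fold (0.35 log units) apart, within the scatter of two such steps. This is consistent with the change carrying over between these cores, but two pairs, with the change at a different place on the ring in each, do not show that its size transfers, and core and place cannot be separated.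

Open, from the compounds shown here alone, is how a chloro group or an amine would read at the same place. Also open, going by these compounds, is whether 2-fluorophenyl to 2-methylphenyl reads the same on the core of compound 2.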